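The source may hold more compounds than are shown below. What is called first, only, known or untested is meant among the compounds shown, and "the series" means these compounds.

In a functional assay on MKN-45 cells (Homo sapiens) for cytotoxicity, read by MTT assay, with a stated time of 72 h (on this read-out lower numbers stand for stronger inhibition and higher numbers for weaker inhibition), compound 3 `CN(C)CCn1cnnc1-c1cc(Oc2ccc(NC(=O)N/N=C/c3ccccc3O[N+](=O)[O-])cc2F)ccn1` gives 1020 nM, the second highest of three numbers. Its nearest neighbour is compound 2 `COc1ccc(/C=N/NC(=O)Nc2ccc(Oc3ccnc(-c4nncn4CCN(C)C)c3)c(F)c2)c(OC)c1`, which gives 1680 nM; the step of a 1.6-fold lower number from compound 2 to compound 3 (0.22 log units; within the scatter) lies within the scatter. Compound 1 `CN(C)CCn1cnnc1-c1cc(Oc2ccc(NC(=O)N/N=C/c3c(Cl)cccc3Cl)cc2F)ccn1` gives 160 nM, and the steps of an 11-fold higher number from compound 1 to compound 2 (1.02 log units; beyond the scatter) and a 6.4-fold higher number from compound 1 to compound 3 (0.80 log units; beyond the scatter) show that replacing the 2,6-dichlorophenyl weakened inhibition in both cases. Compound 4 `COc1cc(/C=N/NC(=O)Nc2ccc(Oc3ccnc(-c4nncn4CCN(C)C)c3)c(F)c2)cc(OC)c1OC` differs from compound 3 by 3,4,5-trimethoxyphenyl in place of 2-(nitrooxy)phenyl on a carbon with a double bond to nitrogen. The closest comparison is between the 2,4-dimethoxyphenyl of compound 2 and the 2-(nitrooxy)phenyl of compound 3, a step that stayed within the scatter, so compound 4 is expected to sit near compound 2. Compound 4 is estimated at 1900 nM, ranging from 700 nM to 6000 nM. The expected step of a 1.9-fold higher number from compound 3 to compound 4 (0.27 log units; within the scatter) would remain within the scatter.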

Compound 4, half-maximal inhibitory concentration: 2900 nM
The estimate for compound 4 lay 1.5-fold (0.18 log units) below the measured number; low and high end bracket the measured number.
By their numbers in this assay, from the lowest: compound 1; then compounds 3, 2 and 4 (each within the scatter of the next, the first and the last beyond it).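

The 3,4,5-trimethoxyphenyl brings a 2.8-fold higher number from compound 3 to compound 4 (0.45 log units; beyond the scatter) and so, unlike the 2,4-dimethoxyphenyl, stands apart from the 2-(nitrooxy)phenyl at this place. The two methoxy-bearing rings remain unseparated, with a 1.7-fold higher number from compound 2 to compound 4 (0.24 log units; within the scatter) as their step, while an 18-fold higher number from compound 1 to compound 4 (1.26 log units; beyond the scatter) is the largest step seen here and leaves the 2,6-dichlorophenyl of compound 1 clearly ahead of all three other groups. No measurement available here explains these differences. Still open, going by these compounds, is how a phenyl carrying a single chlorine, or one carrying an amine, would compare with the 2,6-dichlorophenyl at this place.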